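Ester and thiol swap on a flat series

The source may hold more compounds than are shown below. What is called first, only, known or untested is meant among the compounds shown, and "the series" means these compounds.

- Compound 1 `CC[C@H](C)[C@@H](NCC(=O)NNC(=O)COc1ccc(-c2nc3ccccc3s2)cc1OC)C(=O)O`: 3990 nM
- Compound 2 `COc1cc(-c2nc3ccccc3s2)ccc1OCC(=O)NNC(=O)CN(C(C)=O)[C@@H](CS)C(=O)O`: 3420 nM
- Compound 3 `CCOC(=O)[C@@H](NCC(=O)NNC(=O)COc1ccc(-c2nc3ccccc3s2)cc1OC)[C@@H](C)CC`: 3460 nM

In a functional assay on HepG2 cells (Homo sapiens) for inhibition, read by MTT assay, with a stated time of 3 days (on this read-out lower numbers stand for stronger inhibition and higher numbers for weaker inhibition), compound 3 gives 3460 nM. This value holds no clear rank, since all three measured numbers lie within the usual scatter of one another. The two steps that reach compound 3 show this: a 1.0-fold higher number from compound 2 to compound 3 (0.01 log units; within the scatter), and a 1.2-fold lower number from compound 1 to compound 3 (0.06 log units; within the scatter).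

Compound 4 `CCOC(=O)[C@H](CS)N(CC(=O)NNC(=O)COc1ccc(-c2nc3ccccc3s2)cc1OC)C(C)=O` differs from compound 3 in one place, on a saturated chain carbon bound to a carbonyl carbon: acetyl(1-(ethoxycarbonyl)-2-sulfanylethyl)amino in place of (1-(ethoxycarbonyl)-2-methylbutyl)amino on a saturated chain carbon bound to a carbonyl carbon. The incoming group is acetyl(1-(ethoxycarbonyl)-2-sulfanylethyl)amino, and it replaces (1-(ethoxycarbonyl)-2-methylbutyl)amino.

Among the compounds with values here, the closest precedent is the matching exchange on the free acids, which is a 1.2-fold lower number from compound 1 to compound 2 (0.07 log units; within the scatter). The swap of acid for ethyl ester, already seen above, also stayed within the scatter. Compound 4 carries both changes together, and no measured compound beyond it could show how they combine. Neither precedent points to a real shift, so no step beyond the scatter is expected in this assay. The expected change is a 1.1-fold lower number from compound 3 to compound 4 (0.03 log units; within the scatter). For compound 4 the estimated value is 3200 nM, with an expected range from 1600 nM to 6400 nM.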

Compound 4, half-maximal inhibitory concentration: 3010 nM
Compound 4: the middle estimate sits 1.1-fold (0.03 log units) above what was measured; measured number inside the range.
By their numbers in this assay, from the lowest: compounds 4, 2, 3 and 1 (each within the scatter of the next).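

In this assay, the acetyl(1-(ethoxycarbonyl)-2-sulfanylethyl)amino group gives a 1.1-fold lower number from compound 3 to compound 4 (0.06 log units; within the scatter), so this exchange on a saturated chain carbon bound to a carbonyl carbon stays within the scatter on the ethyl esters, as it did on the free acids. Ethyl in place of hydrogen on an oxygen next to a carbonyl group gives a 1.1-fold lower number from compound 2 to compound 4 (0.06 log units; within the scatter), which extends the ester result, until now seen only with the 2-methylbutyl side chain, to the side chain that carries sulfur. With both changes together, the comparison gives a 1.3-fold lower number from compound 1 to compound 4 (0.12 log units; within the scatter), so even the combined exchange cannot be told apart from repeat-measurement scatter among these compounds. Nothing available explains why these changes leave the number so little altered.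

As far as these compounds go, whether a simple amine, a phenyl ring or a longer carbon chain at this place would carry the number beyond the scatter remains open. The contribution of the sulfur is also unresolved, and a hydroxyl group in its place would be one way to test it.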